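The source may report more compounds than this note shows. Statements on the series, on what has been measured and on what is new or still open speak of the compounds shown alone.

Compound 1 `N#C[Se]c1ccc(NC(=O)Oc2ccccc2)cc1` gives 4000 nM in a functional assay on MCF7 cells (Homo sapiens) for cytotoxicity, read by MTT assay, with a stated time of 72 h; a lower number here means a stronger inhibitor of growth, a higher number a weaker inhibitor of growth. Compound 2 `CCCCCCOC(=O)Nc1ccc([Se]C#N)cc1` gives 6600 nM in this assay.

Among these two numbers compound 2 stands at the higher one, but only by a 1.7-fold higher number from compound 1 to compound 2 (0.22 log units; within the scatter), a gap that falls inside the scatter of the method, so the two compounds cannot be ranked against each other. For the measured compounds named here, that step, which swapped a phenyl for a hexyl group on the carbamate oxygen, is the only measured change, and it is also the one that bears on the next compound.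

Compound 3 `CCCCOC(=O)Nc1ccc([Se]C#N)cc1` shortens the hexyl chain of compound 2: hydrogen in place of ethyl on a saturated chain carbon, four bonds along the chain from an oxygen next to a carbonyl group. Going by the values given here, the one comparable step, a 1.7-fold higher number from compound 1 to compound 2 (0.22 log units; within the scatter), exchanged a whole aromatic ring for a six-carbon chain and still stayed within the scatter, so trimming two carbons from that same chain is expected to move the number even less. No step beyond the scatter is expected in either direction, and compound 3 is estimated at 7000 nM, with a range from 3500 nM to 14000 nM, which amounts to an expected step of a 1.1-fold higher number from compound 2 to compound 3 (0.03 log units; within the scatter).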

Compound 3, concentration for 50% growth inhibition in the MCF7 assay: 6600 nM
Beside the measured number, compound 3's estimate is 1.1-fold (0.03 log units) above it; the measured number falls inside the stated range.
By their numbers in the MCF7 assay, from the lowest: compounds 1, 2 and 3 (each within the scatter of the next).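

In the MCF7 assay, shortening the chain does not register: no change at the digits printed from compound 2 to compound 3 (within the scatter), and the wider swap of the phenyl for a butyl group gives a 1.7-fold higher number from compound 1 to compound 3 (0.22 log units; within the scatter), so none of the three compounds can be ranked against another on growth inhibition. This change does register in a physicochemical assay, with a stated time of 180 min, tested at 0.5 mg/mL (on this read-out higher numbers stand for more inhibition at the one concentration tested (going by the name of the read-out) and lower numbers for less inhibition), and there compound 2 gives > 25%, which is a limit of the assay and not a number. In the physicochemical assay compound 3 gives 6.6%, and a number at least 18.4 percentage points lower from compound 2 to compound 3 (beyond the scatter), so trimming the chain from hexyl to butyl leaves the cell result unmoved but does separate the compounds here, by a gap known only as a minimum: the limit of > 25% in the physicochemical assay, at which 1 of the 2 values shown sits.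

Going by these compounds, it remains open whether a longer chain such as octyl, or a chain carrying an amine or a carboxylic acid, would shift the number in the MCF7 assay beyond the scatter. Two chains also cannot show whether the result in the physicochemical assay follows chain length step by step, and a propyl or a pentyl chain would test this.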